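The source may hold more compounds than are shown below. What is called first, only, known or untested is meant among the compounds shown, and "the series" means these compounds.

Compound 1 `OC[C@H]1O[C@@H](n2cnc3c(NC(C4CCC4)C4CCC4)ncnc32)[C@H](O)[C@@H]1O` — in an ADME assay on Vero 76 cells (Chlorocebus sabaeus) for cytotoxicity, read by neutral red uptake (on this read-out higher numbers stand for lower toxicity in this test and lower numbers for higher toxicity in this test), compound 1 reaches only the limit of > 100000 nM.
Compound 2 `O[C@@H]1[C@H](O)[C@@H]2C[C@@H]2[C@H]1n1cnc2c(NC(C3CCC3)C3CCC3)nc(Cl)nc21` — in this assay compound 2 gives 17000 nM.
Compound 3 `OC[C@@]12C[C@@H]1[C@@H](n1cnc3c(NC(C4CCC4)C4CCC4)nc(Cl)nc31)[C@H](O)[C@@H]2O` — in this assay compound 3 gives 28000 nM.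

Compound 3 holds the higher of the two numbers, and its nearest neighbour is compound 2, separated by a 1.6-fold higher number from compound 2 to compound 3 (0.22 log units; within the scatter). That step exchanges one carbocyclic group for another and so does not touch the change at hand. Compound 4 `OC[C@H]1O[C@@H](n2cnc3c(NC(C4CCC4)C4CCC4)nc(Cl)nc32)[C@H](O)[C@@H]1O` differs from compound 3 by a group of 9 heavy atoms (5 carbon, 4 oxygen; one five-membered non-aromatic ring with 1 hetero atom) in place of a group of 10 heavy atoms (7 carbon, 3 oxygen; one three-membered non-aromatic ring of carbon only, one five-membered non-aromatic ring of carbon only), on an aromatic nitrogen. Within the data shown here, the only measured compound that carries the entering group is compound 1, whose result in this assay is a limit (the limit of > 100000 nM in this assay, at which 1 of the 3 values shown sits). Compound 1 and compound 4 are not a single measured step apart, so that comparison is only indicative. Compound 4 is nevertheless expected to give a higher number than compound 3, a step of a 2.1-fold higher number from compound 3 to compound 4 (0.33 log units; beyond the scatter), with a fair chance that only a limit is recorded. The estimate for compound 4 in this assay is 60000 nM, within 20000 nM to 200000 nM.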

Compound 4, half-maximal cytotoxic concentration: 27000 nM
Compound 4: the middle estimate sits 2.2-fold (0.35 log units) above what was measured, within the range that was stated.
By their numbers in this assay, from the lowest: compounds 2, 4 and 3 (each within the scatter of the next). At a limit, above all of these: compound 1.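

Compound 4 separates the two places in which compound 1 differs from compounds 2 and 3. With chloro on the core, the sugar-like 3,4-dihydroxy-5-(hydroxymethyl)oxolan-2-yl group on the aromatic nitrogen cannot be told apart from either carbocyclic group in this assay: a 1.0-fold lower number from compound 3 to compound 4 (0.02 log units; within the scatter), and a 1.6-fold higher number from compound 2 to compound 4 (0.20 log units; within the scatter), while the change on the aromatic carbon, chloro in place of hydrogen, does register, with an at least 3.7-fold lower number from compound 1 to compound 4 (0.56 log units; beyond the scatter). That last step has only a lower bound, as compound 1 stands at a limit and not at a number: the limit of > 100000 nM in this assay, at which 1 of the 4 values shown sits.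

Open, going by these compounds, is whether another group on that aromatic carbon, such as fluoro, methyl or an amine, would sit with chloro or with hydrogen. Also open, on these data alone, is whether the step from hydrogen to chloro has a similar size with the carbocyclic groups on the aromatic nitrogen.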